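Ring hydroxy on the methoxyphenyl arm of compound 2

The source may hold more compounds than are shown below. What is called first, only, known or untested is meant among the compounds shown, and "the series" means these compounds.

In a functional assay on MCF7 cells (Homo sapiens) for inhibition, read by resazurin assay, with a stated time of 72 h (on this read-out lower numbers stand for stronger inhibition and higher numbers for weaker inhibition), compound 2 `COc1ccc(C2C(O)C(=O)N2c2cc(OC)c(OC)c(OC)c2)cc1` gives 4 nM, the lowest of the three numbers. Compound 1 `C=CC1C(=O)N(c2cc(OC)c(OC)c(OC)c2)C1c1ccc(OC)cc1` gives 17 nM and compound 3 `COc1ccc(C2C(C3CC3)C(=O)N2c2cc(OC)c(OC)c(OC)c2)cc1` gives 120 nM. The steps of a 4.3-fold lower number from compound 1 to compound 2 (0.63 log units; beyond the scatter), a 7.1-fold higher number from compound 1 to compound 3 (0.85 log units; beyond the scatter) and a 30-fold higher number from compound 2 to compound 3 (1.48 log units; beyond the scatter) all concern a substituent on a saturated ring carbon of the shared core. Compound 4 `COc1ccc(C2C(O)C(=O)N2c2cc(OC)c(OC)c(OC)c2)cc1O` differs from compound 2 at another place: hydroxy in place of hydrogen on an aromatic carbon. Going by the values given here, no measured step touches the 4-methoxyphenyl ring, so the three steps give no guide to the direction here, and the expected step is no change at the digits printed from compound 2 to compound 4 (within the scatter). Compound 4 is therefore estimated at 4 nM, with a range from 1.5 nM to 12 nM.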

Compound 4, half-maximal inhibitory concentration: 3 nM
Compound 4: middle estimate off by 1.3-fold (0.12 log units), on the high side; the range from low to high includes it.
By their numbers in this assay, from the lowest: compounds 4 and 2 (each within the scatter of the next); then compound 1; then compound 3.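

Moving away from the saturated ring carbon, 4-methoxyphenyl to 3-hydroxy-4-methoxyphenyl in this assay leaves the number within the scatter (a 1.3-fold lower number from compound 2 to compound 4 (0.12 log units; within the scatter)), whereas all three steps at the saturated ring carbon lie beyond it. With hydroxy on the saturated ring carbon, this aromatic carbon therefore takes a hydroxy without a readable change. No evidence on hand bears on this result.

Going by these compounds, whether an amine or a longer alkoxy chain at this aromatic carbon would also leave the number unchanged stays open. Also open, on these data alone, is whether this hydroxy would give the same result with vinyl or cyclopropyl on the saturated ring carbon.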